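The source may report more compounds than this note shows. Statements on the series, on what has been measured and on what is new or still open speak of the compounds shown alone.

Compound 1 `COc1ccc(CCOc2ccc(-c3c(C)nc(C)c([C@H](OC(C)(C)C)C(=O)O)c3N3CCC(C)(C)CC3)cc2)cc1` carries a 4-methoxyphenyl group on a saturated chain carbon, two bonds along the chain from an oxygen on an aromatic ring. In a toxicity assay on MT2 cells (Homo sapiens) for cytotoxicity, read by XTT assay, with a stated time of 4 days (a higher number here means that more compound is tolerated, a lower number that less compound is tolerated), compound 1 gives only a limit, >= 33500 nM, so what is known of it is a limit and not a number. Compound 2 `Cc1nc(C)c([C@H](OC(C)(C)C)C(=O)O)c(N2CCC(C)(C)CC2)c1-c1ccc(OCCc2ccncc2)cc1` has pyridin-4-yl in the same place. In this assay compound 2 likewise gives only a limit, >= 25000 nM. The step that the two limits leave unreadable from compound 1 to compound 2 thus cannot be read: one value sits at the limit of >= 25000 nM in this assay, at which 1 of the 2 values shown sits, and the other at the limit of >= 33500 nM in this assay, at which 1 of the 2 values shown sits, and the two limits leave its size unknown. Compound 3 `Cc1nc(C)c(CCOc2ccc(-c3c(C)nc(C)c([C@H](OC(C)(C)C)C(=O)O)c3N3CCC(C)(C)CC3)cc2)s1` is the next member of the series; the change from compound 1 is 2,4-dimethyl-1,3-thiazol-5-yl in place of 4-methoxyphenyl on a saturated chain carbon, two bonds along the chain from an oxygen on an aromatic ring. Going by the values given here, the only measured step at this place, from compound 1 to compound 2, bears on it but has no readable size, so no step beyond the scatter is expected in this assay in either direction, and a further limit is the most likely outcome. Compound 3 is estimated at 30000 nM in this assay, within 12000 nM to 60000 nM, the expected step being an at least 1.1-fold lower number from compound 1 to compound 3 (0.04 log units; that floor lies within the scatter).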

Compound 3, half-maximal cytotoxic concentration: >= 25000 nM
Compound 3: only a limit was reported; the forecaster's own chance of this, stated with the estimate: 75%; the middle value lies beyond the limit too.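

In this assay compound 3 gives only a limit, >= 25000 nM, so its steps from compound 1 and to compound 2 cannot be read: the limit of >= 25000 nM in this assay, at which 2 of the 3 values shown sit.

The compounds shown leave open whether 4-methoxyphenyl, pyridin-4-yl and 2,4-dimethyl-1,3-thiazol-5-yl differ at all in this assay, and what half-maximal cytotoxic concentration compound 1, compound 2 or compound 3 actually has.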